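Adding a second chloro to the aryl group of compound 1

The source may report more compounds than this note shows. Statements on the series, on what has been measured and on what is new or still open speak of the compounds shown alone.

compound 1 `Cc1nc2cc(OC[C@H](O)CN3CCN(Cc4noc(-c5ccc(Cl)cc5)n4)CC3)ccc2s1` 2270 nM
compound 2 `Cc1nc2cc(OC[C@H](O)CN3CCN(Cc4coc(-c5ccc(C(F)(F)F)cc5)n4)CC3)ccc2s1` 11000 nM
compound 3 `Cc1nc2cc(OC[C@H](O)CN3CCN(Cc4nc(-c5ccc(C(F)(F)F)cc5)sc4C)CC3)ccc2s1` 1500 nM

Of the compounds shown here, three sharing the same core have been measured in a functional assay on mitochondria from heart for inhibition of peroxisomal acyl-coenzyme A oxidase 1 (Rattus norvegicus); on this read-out higher numbers stand for weaker inhibition and lower numbers for stronger inhibition. Compound 1 gives 2270 nM. Of the three numbers it has the second highest. Its nearest neighbour is compound 3, whose value of 1500 nM lies within the usual scatter of compound 1, so the two cannot be told apart. The furthest is compound 2, which at 11000 nM stands beyond the scatter and gives a clearly higher number than compound 1.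

The unmeasured compound 4 `Cc1nc2cc(OC[C@H](O)CN3CCN(Cc4noc(-c5ccc(Cl)cc5Cl)n4)CC3)ccc2s1` differs from compound 1 in one place: chloro in place of hydrogen on an aromatic carbon. Read one bond further out, the change turns a 4-chlorophenyl into a 2,4-dichlorophenyl. Among the measured compounds shown here, no pair among the measured compounds shows a change of this kind, so there is no step to lean on. For the measured compounds named here, because compound 1 gives 2270 nM and no measured pair shows a change of this kind, the expected step from compound 1 to compound 4 is a 1.3-fold lower number from compound 1 to compound 4 (0.10 log units; within the scatter), a change not expected to reach beyond the scatter. For compound 4 the estimated value in this assay is 1800 nM, with a range from 600 nM to 5500 nM.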

Compound 4, half-maximal inhibitory concentration: 130 nM
For compound 4 the middle estimate is 14-fold (1.14 log units) above the measured one; the measured number lies below the stated range.
By their numbers in this assay, from the lowest: compound 4; then compounds 3 and 1 (each within the scatter of the next); then compound 2.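

In this assay, chloro in place of hydrogen on an aromatic carbon, ortho to a large group, turns the 4-chlorophenyl into a 2,4-dichlorophenyl and gives a 17-fold lower number from compound 1 to compound 4 (1.24 log units; beyond the scatter), a large step well beyond the scatter. Among the compounds shown here, this is the first comparison in the set that differs in one place only, and it shows that this aromatic carbon is far from a silent position: one added chlorine, bringing no ring, no hydrogen-bond donor or acceptor and no net charge, is enough to move the read-out strongly towards stronger inhibition. Nothing available here accounts for the size of this step.

As far as these compounds go, what a fluoro, a methyl or a methoxy group would do on this same aromatic carbon stays open, as does whether chloro there would give a step of this size without the chloro already present in the 4-chlorophenyl. From the compounds shown here alone, it is also open whether the same change would carry over to compound 2 and compound 3, whose aryl groups carry trifluoromethyl instead.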